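The compounds below may be only part of what the source reports. "The series", "measured", "known", "first", "only" and "open" are said of these compounds alone.

Compound 3 `COCc1cc(OC)c(-c2csc3c(N(CC4CC4)CC4CCOC4)c(OC)nn23)c(OC)c1` gives 48 nM in an assay on HEK293 cells for displacement of a labelled ligand from corticotropin-releasing factor receptor 1 (Homo sapiens), read by scintillation proximity assay, with a stated time of 2 h (a lower number here means a stronger inhibitor, a higher number a weaker inhibitor), the lowest of the three numbers measured, though not by a margin that means anything: compound 1 `COCc1cc(OC)c(-c2csc3c(N(CC4CC4)CC4CCCOC4)c(OC)nn23)c(OC)c1` gives 50 nM and compound 2 `COCc1cc(OC)c(-c2csc3c(N(CC4CC4)CC4CCCCO4)c(OC)nn23)c(OC)c1` gives 75 nM, and the steps of a 1.0-fold lower number from compound 1 to compound 3 (0.02 log units; within the scatter) and a 1.6-fold lower number from compound 2 to compound 3 (0.19 log units; within the scatter) both sit inside the scatter, as does a 1.5-fold higher number from compound 1 to compound 2 (0.18 log units; within the scatter). Compound 4 `CCCN(c1c(OC)nn2c(-c3c(OC)cc(COC)cc3OC)csc12)C1CCOCC1` brings a larger change: (oxan-4-yl)(propyl)amino in place of (cyclopropylmethyl)((oxolan-3-yl)methyl)amino on an aromatic carbon. The measured steps only swap one cyclic ether for another on a branch that keeps its cyclopropylmethyl partner; none replaces that partner or drops the linking carbon, so they bear on this step only loosely. Since every change so far stayed within the scatter, a modest step is expected, a 1.9-fold higher number from compound 3 to compound 4 (0.27 log units; within the scatter). Compound 4 is therefore expected to give about 90 nM, with a range from 30 nM to 300 nM.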

Compound 4, half-maximal inhibitory concentration: 98 nM
The estimate for compound 4 lay 1.1-fold (0.04 log units) below the measured number, and the stated range covers the measured number.
By their numbers in this assay, from the lowest: compounds 3, 1, 2 and 4 (each within the scatter of the next, the first and the last beyond it).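

Among the compounds shown here, exchanging the whole branch on this aromatic carbon gives a 2.0-fold higher number from compound 3 to compound 4 (0.31 log units; beyond the scatter) in this assay, the first step in this set to pass the scatter, though only modestly. For the compounds shown here, the amine here can therefore lose its three-membered ring, and carry a six-membered ether ring and a propyl chain, with only that modest change in the number. Nothing available explains the step. Both partners on the nitrogen changed at once, so the compounds shown cannot divide the step between them. Also open, on these data alone, is how a piperidin-4-yl ring in place of oxan-4-yl, or a butyl chain in place of propyl, would read.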